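The source may report more compounds than this note shows. Statements on the series, on what has been measured and on what is new or still open speak of the compounds shown alone.

Compound 2 `CC(C)[C@H](C(=O)Nc1ncns1)c1ccc(Cl)cc1` carries a five-membered aromatic ring on its amide-type nitrogen. For the measured compounds named here, in a functional assay on CHO cells for agonist activity at Free fatty acid receptor 2 (Homo sapiens), read by cAMP accumulation (a higher number here means a larger maximal response, a lower number a smaller maximal response), compound 2 gives 99%, the lowest of the two numbers measured so far. Compound 3 `CC(C)[C@H](C(=O)Nc1nc(C(F)(F)F)cs1)c1ccc(Cl)cc1`, which carries a trifluoromethyl group on its ring, gives 123% in this assay, a gap beyond the usual scatter. Compound 1 `CC(C)C(c1ccc(Cl)cc1)S(=O)(=O)Nc1nccs1` reaches only a limit of this assay, < 30% (the limit of < 30% in this assay, at which 1 of the 3 values shown sits). Compound 4 `CC(C)[C@H](C(=O)Nc1ncc(C#N)s1)c1ccc(Cl)cc1` has not yet been measured. It differs from compound 2 in a single place: 5-cyano-1,3-thiazol-2-yl in place of 1,2,4-thiadiazol-5-yl on an amide-type nitrogen. Going by the values given here, no measured pair shows this exact swap, so the expectation rests on compound 3 and its value of 123%. The step of a number 16 percentage points higher from compound 2 to compound 4 (beyond the scatter) is expected to be modest and upward. Compound 4 is estimated at 115%, between 90% and 140%.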

Compound 4, largest response reached (reported as efficacy), in percent of the reference or control that the assay uses: 105%
The estimate for compound 4 lay 10 percentage points above the measured number; the range from low to high includes it.
By their numbers in this assay, from the lowest: compounds 2 and 4 (each within the scatter of the next); then compound 3. At a limit, below all of these: compound 1.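

In this assay, 5-cyano-1,3-thiazol-2-yl in place of 1,2,4-thiadiazol-5-yl on an amide-type nitrogen gives a number 6 percentage points higher from compound 2 to compound 4 (within the scatter). This is the only single-place step shown, and it indicates that the ring at this position can be exchanged for a larger one carrying a nitrile without a change in maximal response beyond the scatter. No measurement shown here bears on why this is so. From the compounds shown here alone, whether an amine or a carboxylic acid in place of the nitrile would keep this response remains open.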